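From iodo back to methoxy in compound 4

The compounds below may be only part of what the source reports. "The series", "measured", "known", "first", "only" and "open" are said of these compounds alone.

In a functional assay on HT-29 cells (Homo sapiens) for antiproliferative activity, read by sulforhodamine B assay, with a stated time of 48 h (on this read-out lower numbers stand for stronger inhibition and higher numbers for weaker inhibition), compound 1 `CCN1CCN(c2ccc(S(=O)(=O)Oc3ccccc3OC)cc2)C1=O` gives > 100000 nM as a limit of the assay and not a number. Compound 2 `CCN1CCN(c2ccc(S(=O)(=O)Oc3cccc(OC)c3)cc2)C1=O` gives 22000 nM as a measured number. Going by the values given here, compound 3 `CCN1CCN(c2ccc(S(=O)(=O)Oc3cccc(I)c3)cc2)C1=O` gives 3100 nM and holds the lowest number so far. Compound 4 `CCN1CCN(c2ccc(S(=O)(=O)Oc3ccc(OC)cc3)cc2)C1=O` carries 4-methoxyphenyl in place of 3-iodophenyl on an oxygen and awaits measurement. Putting iodo in place of methoxy gave a 7.1-fold lower number from compound 2 to compound 3 (0.85 log units; beyond the scatter) and so a modest gain, which suggests that returning to a methoxy should cost about as much. Moving the methoxy gave an at least 4.5-fold lower number from compound 1 to compound 2 (0.65 log units; beyond the scatter) as well, so its placing counts, but no measured compound yet carries 4-methoxyphenyl. The expected change in this assay is a 4.8-fold higher number from compound 3 to compound 4 (0.68 log units; beyond the scatter) toward weaker inhibition. Compound 4 is estimated at 15000 nM with a range from 3500 nM to 70000 nM on this read-out.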

Compound 4, half-maximal inhibitory concentration: 60000 nM
Estimate against measurement, compound 4: 4.0-fold (0.60 log units) below, within the range that was stated.
By their numbers in this assay, from the lowest: compound 3; then compound 2; then compound 4. At a limit, above all of these: compound 1.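

In this assay the swap of 3-methoxyphenyl for 4-methoxyphenyl gives a real loss (a 2.7-fold higher number from compound 2 to compound 4 (0.44 log units; beyond the scatter)), so 3-methoxyphenyl stays ahead of 4-methoxyphenyl on this oxygen. The larger loss against the iodo compound (a 19-fold higher number from compound 3 to compound 4 (1.29 log units; beyond the scatter)) changes both group and placing at once, so it cannot separate the two. Against 2-methoxyphenyl (an at least 1.6-fold lower number from compound 1 to compound 4 (0.22 log units; that floor lies within the scatter)) no real order can be read, as compound 1 gives only a limit: the limit of > 100000 nM in this assay, at which 1 of the 4 values shown sits.

On these data alone, whether 4-iodophenyl would fall as 4-methoxyphenyl does remains open. So does whether 3-aminophenyl or 3-carboxyphenyl on this oxygen would match the iodo compound.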